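The compounds below may be only part of what the source reports. "The series", "measured", "known", "first", "only" and "open" are said of these compounds alone.

Of the compounds shown here, three have been measured in a functional assay on Huh-7 cells (Homo sapiens) for inhibition, read by sulforhodamine B assay, with a stated time of 72 h; on this read-out lower numbers stand for stronger inhibition and higher numbers for weaker inhibition. Compound 1 `COc1ccc(C(=O)/C=C/c2cn(-c3ccccc3)nc2-c2ccsc2)c(OC)c1OC` gives 4200 nM, compound 2 `COc1ccc(C(=O)/C=C/c2cn(-c3ccccc3)nc2-c2ccsc2)cc1OC` gives 2900 nM, and compound 3 `O=C(/C=C/c1cn(-c2ccccc2)nc1-c1cccnc1)c1ccsc1` gives 1700 nM. Among these, compound 3 holds the lowest number; the step from compound 2 lies within the scatter, while the step from compound 1 lies beyond it. Among the measured compounds shown here, the one measured step, a 1.4-fold lower number from compound 1 to compound 2 (0.16 log units; within the scatter), concerns a change elsewhere in the molecule and does not bear on what follows.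

Compound 4 `COc1ccc(C(=O)/C=C/c2cn(-c3ccccc3)nc2-c2cccnc2)c(OC)c1` differs from compound 3 in one place: 2,4-dimethoxyphenyl in place of thiophen-3-yl on a carbonyl carbon. For the measured compounds named here, no measured step covers this change, and the nearest comparison, compound 2 with its 2900 nM against compound 3, shows no separation beyond the scatter. Compound 4 is therefore expected at about 2500 nM, with a range from 1000 nM to 6000 nM, meaning an expected step of a 1.5-fold higher number from compound 3 to compound 4 (0.17 log units; within the scatter) that stays within the scatter.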

Compound 4, half-maximal inhibitory concentration: 2400 nM
Beside the measured number, compound 4's estimate is 1.0-fold (0.02 log units) above it; measured number inside the range.
By their numbers in this assay, from the lowest: compounds 3, 4, 2 and 1 (each within the scatter of the next, the first and the last beyond it).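

At the carbonyl carbon, 2,4-dimethoxyphenyl in place of thiophen-3-yl gives the first step read at this place, a 1.4-fold higher number from compound 3 to compound 4 (0.15 log units; within the scatter) in this assay for this exchange. A six-membered aromatic ring of carbon only, with 10 heavy atoms, thus stands where a five-membered aromatic ring with 5 heavy atoms stood, and the number stays within the scatter. No evidence at hand speaks to what lies behind this result. The compounds shown leave open whether an amine or a longer chain on this carbonyl carbon would move the number beyond the scatter.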